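The source may report more compounds than this note shows. Statements on the series, on what has been measured and on what is new or still open speak of the compounds shown alone.

Measured compounds:
- compound 1 `COc1cc2c(Oc3ccc(NC(=O)c4nn(-c5ccccc5)c(=O)c5ccccc45)cc3F)ccnc2cc1OCCCN1CCCC1`: 530 nM
- compound 2 `COc1cc2c(Oc3ccc(NC(=O)c4nn(-c5ccccc5Br)c(=O)c5ccccc45)cc3F)ccnc2cc1OCCCN1CCCC1`: 410 nM
- compound 3 `COc1cc2c(Oc3ccc(NC(=O)c4nn(-c5ccccc5)c(=O)c5ccccc45)cc3F)ccnc2cc1OCCCN1CCN(C)CC1`: 620 nM

In a functional assay on MKN-45 cells (Homo sapiens) for cytotoxicity, read by MTT assay, with a stated time of 72 h (on this read-out higher numbers stand for weaker inhibition and lower numbers for stronger inhibition), compound 3 gives the highest of the three numbers, though all three sit close together: compound 1 lies within the scatter of it, and compound 2 also lies within the scatter. The two steps that were measured are small. The step of a 1.3-fold lower number from compound 1 to compound 2 (0.11 log units; within the scatter) and the step of a 1.2-fold higher number from compound 1 to compound 3 (0.07 log units; within the scatter) both fall within the usual scatter, so neither the change at the phenyl ring nor the change at the end of the chain moved the number beyond what repeated measurements would show.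

Compound 4 `COc1cc2c(Oc3ccc(NC(=O)c4nn(-c5ccccc5F)c(=O)c5ccccc45)cc3F)ccnc2cc1OCCCN1CCN(C)CC1` differs from compound 3 by one change: fluoro in place of hydrogen on an aromatic carbon. Going by the values given here, the one measured step that bears on this place is the step from compound 1 to compound 2, where bromo entered on an aromatic carbon ortho to the large group and the number stayed within the scatter. A smaller halogen at the same carbon is therefore expected to behave alike in this assay, with no step beyond the scatter. Compound 4 is estimated at 520 nM, within a range of 250 nM to 1100 nM, which means an expected step of a 1.2-fold lower number from compound 3 to compound 4 (0.08 log units; within the scatter).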

Compound 4, half-maximal inhibitory concentration: 210 nM
Beside the measured number, compound 4's estimate is 2.5-fold (0.39 log units) above it; measured number outside the range, below it.
By their numbers in this assay, from the lowest: compounds 4, 2, 1 and 3 (each within the scatter of the next, the first and the last beyond it).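

In this assay, going by these compounds alone, fluoro in place of hydrogen on the aromatic carbon ortho to a large group gives a 3.0-fold lower number from compound 3 to compound 4 (0.47 log units; beyond the scatter), the first step at this ring position beyond the scatter. The earlier change at this carbon, a 1.3-fold lower number from compound 1 to compound 2 (0.11 log units; within the scatter), stayed within the scatter, but it introduced bromo with pyrrolidin-1-yl at the chain end, whereas the fluoro step has 4-methylpiperazin-1-yl there, so the position can matter, yet the compounds shown cannot separate the choice of halogen from the chain end. Nothing given here explains the drop in the number.

Going by these compounds, it remains open whether phenyl to 2-fluorophenyl gives a similar step when the chain ends in pyrrolidin-1-yl. On these data alone, it is also open how chloro, methyl or methoxy at the same carbon would compare with fluoro.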